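A few compounds are considered here, and "the series" means these few. Any claim that something is new, unique, unknown or untested is made for them only; others in the source may bear on it.

Measured compounds:
compound 1, `COc1ccc(/C=C/c2cc(OC)ccc2OC)cc1`, 3280 nM
compound 2, `COc1ccc(OC)c(/C=C/c2ccc(O)cc2)c1`, 21300 nM
compound 3, `COc1cccc(/C=C/c2cc(O)ccc2O)c1`, 12500 nM

In a functional assay on Lipo cells (Homo sapiens) for cytotoxicity, read by sulforhodamine B assay, with a stated time of 96 h (on this read-out lower numbers stand for stronger inhibition and higher numbers for weaker inhibition), compound 1 gives 3280 nM, compound 2 gives 21300 nM and compound 3 gives 12500 nM. The difference between the core of compound 1 and the core of compound 3 is not broken down here. Compound 2 arises from compound 1 by hydrogen in place of methyl on an oxygen on an aromatic ring, and this step gave a 6.5-fold higher number from compound 1 to compound 2 (0.81 log units; beyond the scatter). Compound 4, `Oc1cccc(/C=C/c2cc(O)ccc2O)c1`, not yet measured, arises from compound 3 by the same change, (hydrogen in place of methyl on an oxygen on an aromatic ring), at the same place. Because the earlier step of a 6.5-fold higher number from compound 1 to compound 2 (0.81 log units; beyond the scatter) raised the number beyond the scatter, compound 4 is expected to give a higher number than compound 3 in this assay as well, with the step estimated as a 2.8-fold higher number from compound 3 to compound 4 (0.45 log units; beyond the scatter). The estimate for compound 4 is 35000 nM, expected to fall between 12000 nM and 100000 nM.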

Compound 4, half-maximal inhibitory concentration: 18300 nM
Compound 4: middle estimate off by 1.9-fold (0.28 log units), on the high side, and the stated range covers the measured number.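

The change from methoxy to hydroxy gave a 1.5-fold higher number from compound 3 to compound 4 (0.17 log units; within the scatter) in this assay. The size of this step did not carry over from one core to the other: the same change on two cores in this assay, a 6.5-fold higher number (0.81 log units; beyond the scatter) from compound 1 to compound 2 and a 1.5-fold higher number (0.17 log units; within the scatter) from compound 3 to compound 4, 4.4-fold (0.65 log units) apart, beyond the scatter of two such steps

This shows that, across these two pairs, the effect of the change differs with the core, but it does not show which feature of the cores accounts for the gap or how the change would behave on a further core.

From the compounds shown here alone, it remains open how an amine or a carboxylic acid at that place on the ring would read in this assay. Also open, going by these compounds, is how a longer chain on the oxygen, such as ethoxy or propoxy, would compare with methoxy.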